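The source may report more compounds than this note shows. Statements on the series, on what has been measured and on what is new or still open speak of the compounds shown alone.

Measured so far in an ADME assay on the whole organism with Oryza sativa as the target, tested at 0.1 uM; a lower number here means a stronger effect, a higher number a weaker effect of the compound at the concentration tested:

compound 1 `Cc1ccccc1NC(=O)N[C@H](C)c1ccccc1` gives 100%
compound 2 `C[C@@H](NC(=O)Nc1ccc(F)cc1)c1ccccc1` gives 98%
compound 3 `C[C@@H](NC(=O)Nc1ccc(F)cc1F)c1ccccc1` gives 100%

Compound 3 stands level with compound 1 at the digits given, the two of them together forming the highest readings of the three, and compound 2 sits within the scatter of both. Among the measured compounds shown here, the only single-point step among the measured compounds is a number 2 percentage points higher from compound 2 to compound 3 (within the scatter), so the one substitution on that ring that has been tested directly left the read-out where it was.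

Compound 4 `Cc1cc(F)ccc1NC(=O)N[C@H](C)c1ccccc1` is the next member. methyl in place of fluoro on an aromatic carbon

For the measured compounds named here, no measured step has a methyl entering in place of a fluoro, so the step to compound 4 has no direct precedent. What the numbers do show is that compound 1, which carries the methyl on that ring without the fluoro, and compound 3, which carries the fluoro without the methyl, give the same reading in this assay, and that adding a fluoro to compound 2 changed nothing beyond the scatter. All three measured compounds sit at or close to the top of the read-out. The step of no change at the digits printed from compound 3 to compound 4 (within the scatter) is therefore expected to fall within the scatter, with no direction beyond it. The estimate for compound 4 in this assay is 100%, with an expected range from 90% to 100%.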

Compound 4, a percentage reported as activity, at one concentration (the size of the read-out at that concentration, not a potency): 100%
Compound 4: middle estimate and measured number agree at the digits printed, within the range that was stated.
By their numbers in this assay, from the lowest: compounds 2, 1, 3 and 4 (each within the scatter of the next).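

Working notes on the series: in this assay, methyl in place of fluoro on the aromatic carbon ortho to a large group gives no change at the digits printed from compound 3 to compound 4 (within the scatter), the first direct reading of this exchange, and it separates the two groups by nothing beyond the scatter. The same place, read as methyl in place of hydrogen with the other fluoro group present, gives a number 2 percentage points higher from compound 2 to compound 4 (within the scatter), so neither methyl nor fluoro at this position has yet shifted the read-out beyond the scatter relative to hydrogen on this background. Fluoro in place of hydrogen now also has a second reading, no change at the digits printed from compound 1 to compound 4 (within the scatter), and the two readings of that change agree: the same change on two cores in this assay, a number 2 percentage points higher (within the scatter) from compound 2 to compound 3 and no change at the digits printed (within the scatter) from compound 1 to compound 4, 2 percentage points apart, within the scatter of two such steps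

Every step among the four compounds lies within the scatter, so they leave open whether any substituent at this position can move the read-out in this assay at all. Whether an amine, a carboxylic acid, a methoxy group or a longer chain on this aromatic carbon would produce a step beyond the scatter remains an open question for the series.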